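Bromo on the Phenyl of Compound 2: An Expected Value

A few compounds are considered here, and "the series" means these few. Any claim that something is new, unique, unknown or untested is made for them only; others in the source may bear on it.

Compound 1 `O=C(Cn1c(-c2ccccc2)cc(-c2ccccc2)c1-c1ccco1)Nc1nc2ccccc2s1` gives 89.9% in an ADME assay on HEK-293T cells (Homo sapiens) for cytotoxicity, read by MTT assay, with a stated time of 72 h, tested at 50 uM; on this read-out higher numbers stand for more inhibition at the one concentration tested (going by the name of the read-out) and lower numbers for less inhibition.
Compound 2 `O=C(Cn1c(-c2ccccc2)cc(-c2ccccc2)c1-c1ccccc1)Nc1nc2ccccc2s1` gives 55% in this assay.
Compound 3 `CCc1nnc(NC(=O)Cn2c(-c3ccccc3)cc(-c3ccccc3)c2-c2ccccc2)s1` gives 49.3% in this assay.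

Compound 2 stands second highest of the three numbers; compound 3 lies within the scatter of it, while compound 1 stands well above it, the step of a number 34.9 percentage points lower from compound 1 to compound 2 (beyond the scatter) being large. Compound 4 `O=C(Cn1c(-c2ccccc2)cc(-c2ccccc2)c1-c1ccc(Br)cc1)Nc1nc2ccccc2s1` differs from compound 2 by bromo in place of hydrogen on an aromatic carbon. Only a number 34.9 percentage points lower from compound 1 to compound 2 (beyond the scatter) touches the same aromatic carbon, and there a whole ring was exchanged, not a single substituent added; a number 5.7 percentage points lower from compound 2 to compound 3 (within the scatter) concerns another part and lies within the scatter. Within the data shown here, no measured step exchanges bromo for hydrogen. Compound 4 is therefore expected to stay near compound 2, with a number 2 percentage points higher from compound 2 to compound 4 (within the scatter) expected to remain within the scatter. Compound 4 is estimated at 57%, between 37% and 77%.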

Compound 4, a percentage reported as inhibition, at one concentration (the size of the read-out at that concentration, not a potency): 86.7%
Estimate against measurement, compound 4: 29.7 percentage points below, and the stated range ends below it.
By their numbers in this assay, from the lowest: compounds 3 and 2 (each within the scatter of the next); then compounds 4 and 1 (each within the scatter of the next).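

The phenyl of compound 2 proves sensitive to a single added heavy atom: in this assay, bromo in place of hydrogen gives a number 31.7 percentage points higher from compound 2 to compound 4 (beyond the scatter) on a single substituent, where earlier only a whole-ring exchange had moved the number this far. Exchanging furan-2-yl for 4-bromophenyl gives a number 3.2 percentage points lower from compound 1 to compound 4 (within the scatter) and so places these two groups level, with unsubstituted phenyl apart from them. Nothing shown gives a reason for either step.

The compounds shown leave open whether this step belongs to bromo itself or would also follow from chloro, methoxy or an amine on the same carbon. They also leave open whether bromo would act alike with the 5-ethyl-1,3,4-thiadiazol-2-yl amide of compound 3.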